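This account rests on a few compounds, and the source may have more. Where it says the series, first, only, none or still open, it means among the compounds named here.

Measured in a functional assay on MCF7 cells (Homo sapiens) for antiproliferative activity, read by MTT assay, with a stated time of 72 h; a lower number here means a stronger inhibitor, a higher number a weaker inhibitor:
- compound 1 `CCCCCCCCCCNC[C@@H]1OC[C@H](N)[C@@H]1O`: 34200 nM
- compound 2 `CCCCCCCCCCCCNC[C@@H]1OC[C@H](N)[C@H]1O`: 12600 nM
- compound 3 `CCCCCCCCCCCNC[C@@H]1OC[C@H](N)[C@H]1O`: 13100 nM

In this assay, compound 3 gives 13100 nM, which lies within the scatter of compound 2. Both stand apart from compound 1, whose number is clearly higher than that of compound 3.

Compound 4 `CCCCCCCCCCNC[C@@H]1OC[C@H](N)[C@H]1O` differs from compound 3 by hydrogen in place of methyl on a saturated chain carbon, ten or more bonds along the chain from an amine nitrogen.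

Going by the values given here, one measured step bears directly on this change. It is the same exchange, hydrogen in place of methyl at the same kind of place: a 1.0-fold higher number from compound 2 to compound 3 (0.02 log units; within the scatter). That step lies within the scatter, so it gives no reason to expect a real shift here. It is a single step, however, and so a thin basis. No measured single change links compound 1 to the other two, so its value does not set the size of this step, though it does show that numbers this high occur among these compounds.

In this assay, the expected outcome is therefore no change beyond the scatter, with the range left somewhat wider on the high side. The estimated step is a 1.1-fold higher number from compound 3 to compound 4 (0.06 log units; within the scatter). For compound 4 the expected value is 15000 nM, with an estimated range from 8000 nM to 30000 nM.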

Compound 4, half-maximal inhibitory concentration: 42700 nM
Beside the measured number, compound 4's estimate is 2.8-fold (0.45 log units) below it; measured number above the stated range.
By their numbers in this assay, from the lowest: compounds 2 and 3 (each within the scatter of the next); then compounds 1 and 4 (each within the scatter of the next).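

In this assay, the exchange of hydrogen for methyl on a saturated chain carbon does not act alike in every chain: it gives a 1.0-fold higher number from compound 2 to compound 3 (0.02 log units; within the scatter), but a 3.3-fold higher number from compound 3 to compound 4 (0.51 log units; beyond the scatter). Hydrogen in place of ethyl at this kind of place gives a 3.4-fold higher number from compound 2 to compound 4 (0.53 log units; beyond the scatter), so the shift beyond the scatter appears only once the chain reaches the length in compound 4. The step of a 1.2-fold higher number from compound 1 to compound 4 (0.10 log units; within the scatter) adds that, with this chain, a stereocentre at a saturated ring carbon drawn S or R leaves the number within the scatter, a reading that rests on a single pair: the fact that compounds 1 and 4 differ only in the configuration as drawn.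

From the compounds shown here alone, whether a still shorter chain would raise the number further, or a longer chain than that of compound 2 would lower it, stays open. Also open, going by these compounds, are whether the drawn configuration matters with the longer chains of compound 2 and compound 3, and what an amide in place of the chain amine would do.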